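Methyl for Acetyl on a Ring Nitrogen: Expected Cytotoxicity

A few compounds are considered here, and "the series" means these few. Any claim that something is new, unique, unknown or untested is made for them only; others in the source may bear on it.

Three compounds sharing one core were tested in an ADME assay on RAW264.7 cells (Mus musculus) for cytotoxicity, read by MTT assay, with a stated time of 48 h, tested at 50 uM; on this read-out lower numbers stand for less inhibition and higher numbers for more inhibition at the one concentration tested (going by the name of the read-out). Compound 1 `CC(=O)N1CCc2c(sc(NC(=O)c3ccc(Cl)cc3)c2C(N)=O)C1` gives 38.4% in this assay. Compound 2 `CN1CCc2c(sc(NC(=O)c3ccc(Cl)cc3)c2C(N)=O)C1` differs from it by methyl in place of acetyl on an amine nitrogen in a ring and gives 38.5% in this assay; the step of a number 0.1 percentage points higher from compound 1 to compound 2 (within the scatter) shows that this change left the read-out essentially where it was. Compound 3 `CC(=O)N1CCc2c(sc(NC(=O)c3ccc(Oc4ccccc4)cc3)c2C(N)=O)C1` carries a different group on its outer aromatic ring, namely (phenoxy in place of chloro on an aromatic carbon), and gives 32.9% in this assay; the step of a number 5.5 percentage points lower from compound 1 to compound 3 (within the scatter) is likewise small, so the two cores behave alike in this assay as far as these numbers go.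

Compound 4 `CN1CCc2c(sc(NC(=O)c3ccc(Oc4ccccc4)cc3)c2C(N)=O)C1` has not yet been measured. It differs from compound 3 by methyl in place of acetyl on an amine nitrogen in a ring, which is the same change that separates compound 1 from compound 2, at the same place on the same ring of the shared core. Since that earlier change produced a number 0.1 percentage points higher from compound 1 to compound 2 (within the scatter), the expectation is that repeating it on the core of compound 3 will again produce a step within the scatter, estimated as a number 0.1 percentage points higher from compound 3 to compound 4 (within the scatter). Compound 4 is therefore expected to give about 33% in this assay, with a likely range from 23% to 43%, resting on the closeness of compound 1 and compound 2 and on the value of compound 3.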

Compound 4, a percentage reported as inhibition, at one concentration (the size of the read-out at that concentration, not a potency): 58.9%
The estimate for compound 4 lay 25.9 percentage points below the measured number; measured number above the stated range.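

In this assay the change of methyl in place of acetyl on an amine nitrogen in a ring did not carry over from one core to the other, and the step it gave on the phenoxy core was a number 26 percentage points higher from compound 3 to compound 4 (beyond the scatter), which sets it apart from the step on the chloro core: the same change on two cores in this assay, a number 0.1 percentage points higher (within the scatter) from compound 1 to compound 2 and a number 26 percentage points higher (beyond the scatter) from compound 3 to compound 4, 25.9 percentage points apart, beyond the scatter of two such steps. Read the other way, phenoxy in place of chloro on an aromatic carbon gave a number 20.4 percentage points higher from compound 2 to compound 4 (beyond the scatter) with methyl on the ring nitrogen, which does not match what the same change did with acetyl there: the same change on two cores in this assay, a number 5.5 percentage points lower (within the scatter) from compound 1 to compound 3 and a number 20.4 percentage points higher (beyond the scatter) from compound 2 to compound 4, 25.9 percentage points apart, beyond the scatter of two such steps. The two changes therefore did not act independently in these four compounds, but this rests on a single set of four compounds at one concentration, and it shows neither the cause of the difference nor whether it holds for other groups.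

The compounds shown leave open whether a methoxy or benzyloxy group on that aromatic carbon would behave like phenoxy or like chloro once methyl sits on the ring nitrogen. They also leave open whether an ethyl or propanoyl group on that nitrogen would follow methyl or acetyl.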